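One added methyl on a potent compound

The source may hold more compounds than are shown below. What is called first, only, known or untested is meant among the compounds shown, and "the series" means these compounds.

Compound 1 `O=C(CN1CCN(c2nnc(Cc3ccncc3)c3ccccc23)CC1)Nc1cccc(Br)c1`: 1.7 nM
Compound 2 `Cc1ccc(F)cc1NC(=O)CN1CCN(c2nnc(Cc3ccccc3)c3ccccc23)CC1`: 19200 nM
Compound 3 `O=C(CN1CCN(c2nnc(Cc3ccncc3)c3ccccc23)CC1)Nc1cccc(F)c1`: 4.4 nM

All three were measured in a functional assay on MDA-MB-231 cells (Homo sapiens) for cytotoxicity, read by MTT assay, with a stated time of 72 h; on this read-out lower numbers stand for stronger inhibition and higher numbers for weaker inhibition. Among them, compound 3 gives 4.4 nM, the second highest of the three numbers, lying close to compound 1 and far under compound 2.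

Compound 4 `Cc1ccc(F)cc1NC(=O)CN1CCN(c2nnc(Cc3ccncc3)c3ccccc23)CC1` comes from compound 3 through a single change: methyl in place of hydrogen on an aromatic carbon. Put another way, 3-fluorophenyl becomes 5-fluoro-2-methylphenyl.

Among the compounds with values here, only one measured step involves this phenyl group: a 2.6-fold higher number from compound 1 to compound 3 (0.41 log units; beyond the scatter). That step was modest, but it swaps one halogen for another and does not add a methyl, so it is only a loose guide to the size of the change here. Compound 2 already carries the 5-fluoro-2-methylphenyl group and gives 19200 nM, but it also differs from compound 4 elsewhere in the molecule. Within the data shown here, no measured pair isolates the methyl, so this high number serves only as a warning and widens the upper side of the range.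

A modest move toward weaker inhibition is expected, and the estimated change is a 2.0-fold higher number from compound 3 to compound 4 (0.31 log units; beyond the scatter). For compound 4 the estimated value is 9 nM, with an expected range from 1.5 nM to 80 nM.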

Compound 4, half-maximal inhibitory concentration: 6.4 nM
The estimate for compound 4 lay 1.4-fold (0.15 log units) above the measured number; the range from low to high includes it.
By their numbers in this assay, from the lowest: compound 1; then compounds 3 and 4 (each within the scatter of the next); then compound 2.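

In this assay, methyl in place of hydrogen on this aromatic carbon, ortho to a large group and para to the fluoro group, gives a 1.5-fold higher number from compound 3 to compound 4 (0.16 log units; within the scatter) and so leaves no change that can be told apart from repeat measurement. Compounds 2 and 4 share the 5-fluoro-2-methylphenyl group, and pyridin-4-yl in place of phenyl on the saturated chain carbon gives a 3000-fold lower number from compound 2 to compound 4 (3.48 log units; beyond the scatter) as the only difference, so the very high number of compound 2 cannot be laid on the added methyl or this phenyl group alone. Compared directly, 5-fluoro-2-methylphenyl in place of 3-bromophenyl on the amide-type nitrogen gives a 3.8-fold higher number from compound 1 to compound 4 (0.58 log units; beyond the scatter) and is a modest step, larger than the scatter but tiny beside the step at the pyridin-4-yl position.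

The compounds shown leave open whether this same carbon would accept anything bigger or different from methyl, such as ethyl, methoxy or an amine, and whether methyl would behave the same way with bromo rather than fluoro on the ring. Nothing available explains the size of any of these steps.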